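The compounds below may be only part of what the source reports. "The series", "measured", "known", "first", "only" and "open" are said of these compounds alone.

Compound 1 `CCOC(=O)c1c(C)nc(NCCCNc2ccnc3cc(Cl)ccc23)nc1-c1ccccc1` has been examined in an ADME assay on HEL cells (Homo sapiens) for cytotoxicity, read by microscopy; on this read-out lower numbers stand for higher toxicity in this test and higher numbers for lower toxicity in this test. In this assay compound 1 returns only a limit, > 20000 nM. Compound 2 `CCOC(=O)c1c(C)nc(NCCCCNc2ccnc3cc(Cl)ccc23)nc1C` also returns only a limit in this assay, > 20000 nM. Both results sit at the limit of > 20000 nM in this assay, at which 2 of the 2 values shown sit, so neither compound stands apart from the other on the numbers shown. Compound 3 `CCOC(=O)c1c(C)nc(NCCCNc2ccnc3cc(Cl)ccc23)nc1C` differs from compound 1 by methyl in place of phenyl on an aromatic carbon. Among the measured compounds shown here, no step between measured compounds is known here, so the expected step that the limit leaves unreadable from compound 1 to compound 3 is none beyond the scatter. Compound 3 is therefore estimated to give about 25000 nM in this assay, within 10000 nM to 60000 nM, most likely once more only as a limit.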

Compound 3, minimum cytotoxic concentration: >= 100000 nM
Compound 3 ended at the assay's limit; the forecaster's own chance of this, stated with the estimate: 85%; middle value at least 4.0-fold (0.60 log units) away from the limit.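

Compound 1 and compound 3 both return only limits in this assay, so the step between them cannot be read. Going by these compounds, whether phenyl or methyl at this place gives lower toxicity remains open, as does the concentration at which either compound becomes toxic.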